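This account rests on a few compounds, and the source may have more. Where it says the series, first, only, none or still open, it means among the compounds named here.

Measured in a functional assay on A549 cells (Homo sapiens) for inhibition, read by MTT assay, with a stated time of 48 h; on this read-out lower numbers stand for stronger inhibition and higher numbers for weaker inhibition:

Compound 1 `CCNC(=O)/C=C/c1c(/C=C/c2ccc(OC)cc2)cc(OC)cc1OC`: 7860 nM
Compound 2 `COc1ccc(/C=C/c2cc(OC)cc(OC)c2/C=C/C(=O)Nc2cc(OC)c(OC)c(OC)c2)cc1`: 5140 nM

Within the data shown here, compound 2 gives the smaller of the two figures, but the only measured step, a 1.5-fold lower number from compound 1 to compound 2 (0.18 log units; within the scatter), is within the scatter, so the two compounds are not really separated by these numbers. That step put a 3,4,5-trimethoxyphenyl where an ethyl had been on the amide-type nitrogen.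

Compound 3 `CCCCCCNC(=O)/C=C/c1c(/C=C/c2ccc(OC)cc2)cc(OC)cc1OC` has not yet been measured. It differs from compound 2 at the same position: hexyl in place of 3,4,5-trimethoxyphenyl on an amide-type nitrogen. Among the measured compounds shown here, the one measured step bears on this only loosely, since it shows that swapping the ethyl of compound 1 for the 3,4,5-trimethoxyphenyl of compound 2 moved the number by no more than the scatter. Going back to an alkyl chain, now hexyl, is the reverse direction of that step, extended by a longer chain, and nothing measured here speaks to chain length. The expected step in this assay is therefore a 1.3-fold higher number from compound 2 to compound 3 (0.10 log units; within the scatter), that is, nothing beyond the scatter. Compound 3 is accordingly estimated at 6500 nM, with a range from 2500 nM to 17000 nM.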

Compound 3, half-maximal inhibitory concentration: 6230 nM
Compound 3: the middle estimate sits 1.0-fold (0.02 log units) above what was measured; low and high end bracket the measured number.
By their numbers in this assay, from the lowest: compounds 2, 3 and 1 (each within the scatter of the next).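

In this assay, hexyl in place of 3,4,5-trimethoxyphenyl on the amide-type nitrogen gives a 1.2-fold higher number from compound 2 to compound 3 (0.08 log units; within the scatter) and lengthening the ethyl chain to hexyl gives a 1.3-fold lower number from compound 1 to compound 3 (0.10 log units; within the scatter) so neither change separates the compounds. The earlier pair compared only ethyl with 3,4,5-trimethoxyphenyl, whereas this result adds a change in chain length and shows that ethyl, hexyl and 3,4,5-trimethoxyphenyl all give numbers within the scatter of one another, even though one group carries an aromatic ring and the other two are plain carbon chains with no ring. Nothing available explains why such different groups on this nitrogen give numbers so close together.

On these data alone, whether any group at this position can move the number beyond the scatter stays open: a chain ending in an amine or a carboxylic acid, a chain longer than hexyl, or a plain phenyl without methoxy groups would each test this. All three compounds also share the same core, so these results say nothing about how a change to the core, such as removing one of its methoxy groups, would read in this assay.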